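A few compounds are considered here, and "the series" means these few. Any claim that something is new, unique, unknown or untested is made for them only; others in the source may bear on it.

Measured so far in an assay on isolated protein for inhibition of Amine oxidase [flavin-containing] B (Homo sapiens), read by fluorescence and spectrophotometry; on this read-out lower numbers stand for stronger inhibition and higher numbers for weaker inhibition:

Compound 1 `Cc1ccc(C(=O)NCc2cn(Cc3ccc4oc(-c5ccc(Cl)cc5)cc(=O)c4c3)nn2)cc1`: 32900 nM
Compound 2 `O=C(NCc1cnnn1Cc1ccc2oc(-c3ccc(Cl)cc3)cc(=O)c2c1)c1ccccc1`: 32900 nM
Compound 3 `O=C(CCCCc1cn(Cc2ccc3oc(-c4ccccc4)cc(=O)c3c2)nn1)Nc1ccc(F)cc1`: 15600 nM

Compound 1 is level with compound 2 at the digits shown, and together they give the highest two of the three numbers; the gap between them lies within the scatter. Compound 3 gives a lower number, and its gap to compound 1 lies beyond the scatter, although compound 3 differs from compound 1 in more than one place, so nothing about any single change can be drawn from that pair.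

Compound 4 `Cc1ccc(NC(=O)CCc2cn(Cc3ccc4oc(-c5ccc(Cl)cc5)cc(=O)c4c3)nn2)cc1` differs from compound 1 in a single place: ((4-methylphenyl)carbamoyl)methyl in place of ((4-methylphenyl)carbonyl)amino on a saturated chain carbon bound to an aromatic carbon. For the measured compounds named here, no pair of measured compounds shows the effect of this change in this assay, so the size of the step can only be guessed. Compound 3, which also carries a carbamoyl linkage to a phenyl ring on a chain, gives 15600 nM, but its other differences from compound 1 leave that hint weak. A small step toward a lower number, not clearly beyond the scatter, is expected, so that the estimated change a 1.6-fold lower number from compound 1 to compound 4 (0.22 log units; within the scatter) stays modest. Compound 4 is expected to give about 20000 nM, with a likely range from 8000 nM to 55000 nM.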

Compound 4, half-maximal inhibitory concentration: 32900 nM
Compound 4: middle estimate off by 1.6-fold (0.22 log units), on the low side, and the stated range covers the measured number.
By their numbers in this assay, from the lowest: compound 3; then compounds 1, 2 and 4 (each within the scatter of the next).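

In this assay, putting ((4-methylphenyl)carbamoyl)methyl in place of ((4-methylphenyl)carbonyl)amino on a saturated chain carbon bound to an aromatic carbon gives no change at the digits printed from compound 1 to compound 4 (within the scatter). For the compounds shown here, this is the first step that can be read at a single place, and it shows that this exchange, which keeps the 4-methylphenyl ring and the count of hydrogen-bond donors and acceptors while adding to the heavy atoms, leaves the number unmoved at this position. No measurement on hand offers an explanation for this lack of change, so the result stands as an observation only.

The one exchange shown cannot tell whether the position is insensitive in general, and it remains open whether a longer chain, a primary amine or a carboxylic acid in place of these groups would move the number in this assay. Compound 3 differs from the others in more than one place, so the steps that would connect it to them cannot be read, and what its chain or its fluorophenyl amide contributes stays unresolved.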